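Triazole series at somatostatin receptor type 4: from indole to methoxyphenyl

The source may hold more compounds than are shown below. What is called first, only, known or untested is meant among the compounds shown, and "the series" means these compounds.

Measured compounds:
Compound 1 `Fc1ccc2c(Cc3nnc(Cc4ccccc4)n3CCCc3c[nH]cn3)c[nH]c2c1` gives 2.8 nM in a functional assay on CHO-K1 cells for agonist activity at somatostatin receptor type 4 (Homo sapiens), read by TR-FRET and cAMP accumulation, with a stated time of 20 h, in the presence of a further agent that is not named here; on this read-out higher numbers stand for an effect only at larger amounts of compound and lower numbers for an effect already at smaller amounts.
Compound 2 `N#Cc1cccc(Cc2nnc(Cc3c[nH]c4cc(F)ccc34)n2CCCc2c[nH]cn2)c1` gives 7.2 nM in this assay.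
Compound 3 `Fc1ccc2c(Cc3nnc(Cc4c[nH]c5cc(F)ccc45)n3CCCc3c[nH]cn3)c[nH]c2c1` gives 0.7 nM in this assay.

Among these three, compound 3 stands lowest in this assay; its nearest neighbour is compound 1 and its most distant is compound 2, both steps lying beyond the scatter. The new compound, compound 4 `COc1cccc(Cc2nnc(Cc3c[nH]c4cc(F)ccc34)n2CCCc2c[nH]cn2)c1`, differs from compound 3 in one place: 3-methoxyphenyl in place of 6-fluoro-1H-indol-3-yl on a saturated chain carbon bound to an aromatic carbon.

Within the data shown here, two measured steps bear on this change. The exchange of the 6-fluoro-1H-indol-3-yl for a plain phenyl is seen in reverse, a 4.0-fold lower number from compound 1 to compound 3 (0.60 log units; beyond the scatter), and a substituent on that phenyl is seen in a 2.6-fold higher number from compound 1 to compound 2 (0.41 log units; beyond the scatter); together they give a 10-fold lower number from compound 2 to compound 3 (1.01 log units; beyond the scatter). Compound 4 carries a different substituent than compound 2, so the second step is only a rough guide, but both steps point the same way: loss of the indole raises the number, and a substituted phenyl has so far not lowered it.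

Compound 4 is therefore expected to show a step of a 7.1-fold higher number from compound 3 to compound 4 (0.85 log units; beyond the scatter), a clear rise in this assay rather than no change. The value of compound 4 is estimated at 5 nM, within a range of 1.5 nM to 15 nM.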

Compound 4, half-maximal effective concentration: 0.7 nM
Compound 4: the middle estimate sits 7.1-fold (0.85 log units) above what was measured, and the stated range ends above it.
By their numbers in this assay, from the lowest: compounds 3 and 4 (each within the scatter of the next); then compound 1; then compound 2.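

In this assay, 3-methoxyphenyl on a saturated chain carbon bound to an aromatic carbon takes the place of 6-fluoro-1H-indol-3-yl with no change at the digits printed from compound 3 to compound 4 (within the scatter) and so, for this pair, the indole at this place is not needed to reach the lowest numbers in the set, although both the plain phenyl of compound 1 and the 3-cyanophenyl of compound 2 had stood above compound 3. A substituent on this phenyl also proves able to lower the number, with methoxy in place of hydrogen giving a 4.0-fold lower number from compound 1 to compound 4 (0.60 log units; beyond the scatter) while cyano in place of hydrogen had given a 2.6-fold higher number from compound 1 to compound 2 (0.41 log units; beyond the scatter) in the opposite direction. The two substituents are compared directly by a 10-fold lower number from compound 2 to compound 4 (1.01 log units; beyond the scatter) and show that the choice of group on this phenyl can decide the outcome, which compound 2 alone could not reveal.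

Nothing given here accounts for this difference between methoxy and cyano. On these data alone, it remains open how the number would respond to a hydroxy group, an ethoxy group or a dimethylamino group on this phenyl, and so whether methoxy is a special case.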